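Capping a Phenol Oxygen: From Compound 2 to Compound 4

This account rests on a few compounds, and the source may have more. Where it says the series, first, only, none or still open, it means among the compounds named here.

Of the compounds shown here, three built on one shared core have been measured in a functional assay on SF-268 cells (Homo sapiens) for inhibition, read by sulforhodamine B assay, with a stated time of 48 h, tested at 100 uM; a higher number here means a weaker effect of the compound at the concentration tested, a lower number a stronger effect. Compound 1 `O=C(Nc1cccc(-n2cc(-c3ccncc3)c(-c3cc(O)cc(Cl)c3)n2)c1)Nc1ccc(Cl)c(C(F)(F)F)c1` gives -27%, compound 2 `O=C(Nc1cccc(-n2cc(-c3ccncc3)c(-c3cc(O)cc(Cl)c3)n2)c1)Nc1ccc(Cl)c(Cl)c1` gives -11%, and compound 3 `COc1cc(Cl)cc(-c2nn(-c3cccc(NC(=O)Nc4cc(C(F)(F)F)cc(C(F)(F)F)c4)c3)cc2-c2ccncc2)c1` gives -88%. Compound 2 therefore stands at the highest of the three numbers, which means the weakest effect at the tested concentration; its nearest neighbour is compound 1 and its furthest is compound 3, both beyond the scatter. Among the measured compounds shown here, the only single-place step measured so far, a number 16 percentage points higher from compound 1 to compound 2 (beyond the scatter), concerns the aromatic group on the urea side of the molecule and does not touch the oxygen.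

Compound 4 `COc1cc(Cl)cc(-c2nn(-c3cccc(NC(=O)Nc4ccc(Cl)c(Cl)c4)c3)cc2-c2ccncc2)c1` differs from compound 2 in one place: methyl in place of hydrogen on an oxygen on an aromatic ring. For the measured compounds named here, no measured step covers this hydroxy to methoxy change. Compound 3 does carry the methoxy group, but it also carries a different urea aryl, so its strong value of -88% cannot be attributed to the methoxy alone. With no direct guide, the expectation stays near no change beyond the scatter, but with wide uncertainty leaning toward a stronger effect. Compound 4 is therefore expected to give -30%, within -75% to 5%, an expected shift of a number 19 percentage points lower from compound 2 to compound 4 (beyond the scatter).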

Compound 4, a percentage reported as activity, at one concentration (the size of the read-out at that concentration, not a potency): 11%
Beside the measured number, compound 4's estimate is 41 percentage points below it; the measured number lies above the stated range.
By their numbers in this assay, from the lowest: compound 3; then compound 1; then compound 2; then compound 4.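

In this assay, among the compounds shown here, the methyl cap on the phenol oxygen gives a number 22 percentage points higher from compound 2 to compound 4 (beyond the scatter) and is the first measured step at this oxygen, showing that here the change moves toward a weaker effect at the tested concentration. It also shows that the methoxy group does not bring a strong effect on its own: compound 3 gives -88% with that group, whereas compound 4 gives 11% with the same group and a different aryl group on the urea, so the urea aryl group must matter alongside the methoxy group in these two compounds. Nothing in the available data accounts for the direction or size of this step.

The compounds shown leave open whether the same hydroxy to methoxy change would move the number the same way and by a similar amount with the urea aryl group of compound 1 or of compound 3, since each of these appears with only one of the two oxygen forms. They also leave open what a longer chain on this oxygen, such as ethyl, would do, or an amine standing in place of the hydroxy group.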